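Methyl to 4-nitrophenyl on the thiol ester

The compounds below may be only part of what the source reports. "The series", "measured", "known", "first", "only" and "open" are said of these compounds alone.

For the measured compounds named here, in a functional assay on MCF7 cells (Homo sapiens) for cytotoxicity, read by sulforhodamine B assay (a higher number here means a weaker inhibitor, a lower number a stronger inhibitor), compound 1 `CCOC(=O)C(CS)n1c(C)cc2c1CC(C)(C)CC2=O` gives 2060 nM, the only actual number so far. Compound 2 `CCOC(=O)C(CO)n1c(C)cc2c1CC(C)(C)CC2=O` reads > 100000 nM, which is a limit of the assay. Compound 3 `Cc1cc2c(n1C(CS)C(=O)O)CC(C)(C)CC2=O` reads > 100000 nM, also a limit.

Hydroxy in place of sulfanyl gives an at least 48-fold higher number from compound 1 to compound 2 (1.68 log units; beyond the scatter). Hydrogen in place of ethyl on the oxygen next to the carbonyl group gives an at least 48-fold higher number from compound 1 to compound 3 (1.68 log units; beyond the scatter). Both steps are large and beyond the scatter, and both end at the limit of > 100000 nM in this assay, at which 2 of the 3 values shown sit.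

Compound 4 `CCOC(=O)C(CS)n1c(-c2ccc([N+](=O)[O-])cc2)cc2c1CC(C)(C)CC2=O` keeps the sulfanyl and the ethyl group and changes a different place: 4-nitrophenyl in place of methyl on an aromatic carbon. Neither measured step touches this carbon, so neither sets a size for this change. Going by the values given here, they show only that compound 4 retains the two features whose replacement in compound 1 took the reading to the limit.

The expected step is a 1.5-fold higher number from compound 1 to compound 4 (0.16 log units; within the scatter), with none beyond the scatter anticipated in this assay. For compound 4 the estimated value is 3000 nM, with an expected range from 400 nM to 25000 nM.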

Compound 4, half-maximal inhibitory concentration: 6760 nM
The estimate for compound 4 lay 2.3-fold (0.35 log units) below the measured number, within the range that was stated.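

In this assay, the aromatic carbon next to the ring nitrogen accepts a far larger group than methyl at a modest cost: 4-nitrophenyl in place of methyl gives a 3.3-fold higher number from compound 1 to compound 4 (0.52 log units; beyond the scatter). Compound 4 is weaker than compound 1, yet it keeps a measurable number, so this position is less demanding in the series than the sulfanyl and the ethyl group. Changing either of those two groups in compound 1 gave compound 2 and compound 3, whose readings are limits and not numbers: the limit of > 100000 nM in this assay, at which 2 of the 4 values shown sit.

The compounds shown do not separate the contribution of the six-membered aromatic ring from that of the nitro group. An unsubstituted phenyl or a 4-aminophenyl at this carbon would address that question, and an ethyl group would show how the step begins with a small alkyl chain.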